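Replacing propanoyl with methylsulfonyl on an amine nitrogen

The compounds below may be only part of what the source reports. "The series", "measured", "known", "first", "only" and "open" are said of these compounds alone.

Values in an ADME assay on microsomes from liver (Mus musculus) for metabolic stability, read by LC-MS, using NADPH, with stated times of 10 min and 30 min; a higher number here means faster removal of the compound, a lower number slower removal:
- Compound 1 `CCS(=O)(=O)N[C@@H]1CCCc2c1cncc2N1Cc2cc(Cl)ccc2C1=O`: 27 mL/min/kg
- Compound 2 `CCC(=O)N[C@@H]1CCCc2c1cncc2N1Cc2cc(Cl)ccc2C1=O`: < 20.2 mL/min/kg (a limit of the assay)
- Compound 3 `CS(=O)(=O)N[C@@H]1CCCc2c1cncc2N1Cc2cc(Cl)ccc2C1=O`: not yet measured

Compound 2 has no exact number in this assay, only the limit < 20.2 mL/min/kg. The next compound carries methylsulfonyl in place of propanoyl on an amine nitrogen. Among the compounds with values here, one measured step bears on this change, an at least 1.3-fold lower number from compound 1 to compound 2 (0.12 log units; that floor lies within the scatter). As far as these compounds go, that step is only a floor, so its true size remains open. Compound 1 carries ethylsulfonyl rather than methylsulfonyl, and it gives 27 mL/min/kg. Read in reverse, the measured step points to a slightly higher number on returning to a sulfonyl group, though probably no more than the scatter. The expected step is an at least 1.0-fold higher number from compound 2 to compound 3 (0.03 log units; that floor lies within the scatter). Compound 3 may also be reported only at the limit of < 20.2 mL/min/kg in this assay, at which 1 of the 2 values shown sits. For compound 3 the estimate is 22 mL/min/kg, with an expected range of 15 mL/min/kg to 35 mL/min/kg.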

Compound 3, clearance: < 20.2 mL/min/kg
Compound 3 gave a limit, no number (the forecaster's own chance of this, stated with the estimate: 40%); at least 1.0-fold (0.03 log units) between middle value and limit.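

Compound 3 shows that a sulfonyl group on this amine nitrogen can also end at a limit rather than a number in this assay and that the exact number of compound 1 does not hold for sulfonyl groups as such. Going from ethylsulfonyl to methylsulfonyl gives an at least 1.3-fold lower number from compound 1 to compound 3 (0.12 log units; that floor lies within the scatter) and the true size of that floor remains open. The step between propanoyl and methylsulfonyl cannot be read, and the results now gather at one end of the scale: the limit of < 20.2 mL/min/kg in this assay, at which 2 of the 3 values shown sit.

As far as these compounds go, how far compound 2 and compound 3 lie beyond that limit stays unknown, so propanoyl and methylsulfonyl cannot be ranked. From the compounds shown here alone, whether a longer chain such as propylsulfonyl, or a free amine in place of these groups, would give an exact number in this assay also remains open.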